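Methylating the phenol of compound 1: an untested step

The compounds below may be only part of what the source reports. "The series", "measured", "known", "first", "only" and "open" are said of these compounds alone.

Measured so far:
- compound 1, `O=C(Nc1cccc(-n2cc(-c3ccncc3)c(-c3cc(O)cc(Cl)c3)n2)c1)Nc1ccc(Cl)c(C(F)(F)F)c1`: -38%
- compound 2, `O=C(Nc1cccc(-n2cc(-c3ccncc3)c(-c3cc(O)cc(Cl)c3)n2)c1)Nc1ccc(Cl)c(Cl)c1`: -41%

In a functional assay on NCI-H226 cells (Homo sapiens) for inhibition, read by sulforhodamine B assay, with a stated time of 48 h, tested at 100 uM (on this read-out lower numbers stand for a stronger effect and higher numbers for a weaker effect at the one concentration tested), compound 1 gives -38%, the highest of the two numbers, and compound 2 gives -41%. The two differ by a number 3 percentage points lower from compound 1 to compound 2 (within the scatter), which lies within the scatter, so the two compounds cannot be told apart on this read-out.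

Compound 3, `COc1cc(Cl)cc(-c2nn(-c3cccc(NC(=O)Nc4ccc(Cl)c(C(F)(F)F)c4)c3)cc2-c2ccncc2)c1`, has not been measured. It differs from compound 1 by methyl in place of hydrogen on an oxygen on an aromatic ring. Among the measured compounds shown here, the only measured step, from compound 1 to compound 2, concerns a different part of the molecule, so no measured step bears on this change, and nothing here shows how this assay responds to it. The expectation for compound 3 therefore rests on compound 1 alone, with a wide range allowed in either direction. Compound 3 is expected to give about -20%, between -50% and 20%, an estimated step of a number 18 percentage points higher from compound 1 to compound 3 (beyond the scatter).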

Compound 3, a percentage reported as activity, at one concentration (the size of the read-out at that concentration, not a potency): -29%
Estimate against measurement, compound 3: 9 percentage points above, and the stated range covers the measured number.
By their numbers in this assay, from the lowest: compounds 2, 1 and 3 (each within the scatter of the next, the first and the last beyond it).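

Among the compounds shown here, on the oxygen on the aromatic ring, hydroxy to methoxy is the one change here that touches this position, and in this assay it reads as a number 9 percentage points higher from compound 1 to compound 3 (within the scatter). Compound 1 and compound 3 therefore cannot be told apart at the one concentration tested, so on this read-out the hydrogen of the hydroxy group is not shown to be required: a methyl can stand in its place with the effect remaining within the usual scatter. No measurement available here accounts for this result.

The compounds shown leave open whether a longer chain on this oxygen, such as ethoxy, or an amine in place of the hydroxy group would also stay within that scatter. They also leave open whether methoxy would read the same way on the core of compound 2.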